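Thiophen-2-yl Replaces 3-Fluorophenyl in a Cytotoxicity Series

The source may report more compounds than this note shows. Statements on the series, on what has been measured and on what is new or still open speak of the compounds shown alone.

Of the compounds shown here, three sharing one core have been measured so far. Compound 1 `COc1cc(CC(O)c2ccc(-c3ccc(C)cc3)cc2)c([N+](=O)[O-])cc1OC` gives 4700 nM in an ADME assay on HeLa Rh cells (Homo sapiens) for cytotoxicity, read by microscopy; on this read-out lower numbers stand for higher toxicity in this test and higher numbers for lower toxicity in this test. Compound 2 `COc1cc(CC(O)c2ccc(-c3ccc(F)cc3)cc2)c([N+](=O)[O-])cc1OC` gives 4500 nM in this assay, and compound 3 `COc1cc(CC(O)c2ccc(-c3cccc(F)c3)cc2)c([N+](=O)[O-])cc1OC` gives 7400 nM. The steps between them are all small: a 1.0-fold lower number from compound 1 to compound 2 (0.02 log units; within the scatter), a 1.6-fold higher number from compound 1 to compound 3 (0.20 log units; within the scatter) and a 1.6-fold higher number from compound 2 to compound 3 (0.22 log units; within the scatter). Compound 3 therefore cannot be set apart from compound 1 or compound 2 on the numbers shown; the three values sit together within the usual scatter.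

Compound 4 `COc1cc(CC(O)c2ccc(-c3cccs3)cc2)c([N+](=O)[O-])cc1OC` differs from compound 3 in one place: thiophen-2-yl in place of 3-fluorophenyl on an aromatic carbon. Within the data shown here, no measured step exchanges a six-membered aromatic ring of carbon only for a five-membered aromatic ring with a hetero atom, so the bearing of the earlier steps is indirect. The steps that come closest are those that alter the group on this same aromatic carbon, a 1.6-fold higher number from compound 1 to compound 3 (0.20 log units; within the scatter) and a 1.6-fold higher number from compound 2 to compound 3 (0.22 log units; within the scatter), and neither reached beyond the scatter. On that basis, the author expects that the step of a 1.3-fold lower number from compound 3 to compound 4 (0.13 log units; within the scatter) will likewise stay within the scatter, with no clear direction. Compound 4 is accordingly estimated at 5500 nM in this assay, with a range from 2500 nM to 12000 nM.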

Compound 4, half-maximal cytotoxic concentration: 11000 nM
Estimate against measurement, compound 4: 2.0-fold (0.30 log units) below, and the stated range covers the measured number.
By their numbers in this assay, from the lowest: compounds 2, 1, 3 and 4 (each within the scatter of the next, the first and the last beyond it).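

In this assay, among these compounds, thiophen-2-yl on this aromatic carbon, para to a large group, gives the first steps that pass the scatter: a 2.4-fold higher number from compound 2 to compound 4 (0.39 log units; beyond the scatter) and a 2.3-fold higher number from compound 1 to compound 4 (0.37 log units; beyond the scatter) are both modest and point to lower toxicity in this test, whereas the exchanges among the earlier aryl groups all stayed within the scatter. Against 3-fluorophenyl the same exchange separates nothing, at a 1.5-fold higher number from compound 3 to compound 4 (0.17 log units; within the scatter) and so within the scatter, which shows that a five-membered aromatic ring with a hetero atom is accepted here in place of a six-membered aromatic ring of carbon only, with the read-out staying in the range of compound 3. Nothing available explains why the thiophen-2-yl group stands clear of 4-fluorophenyl and 4-methylphenyl but not of 3-fluorophenyl.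

The compounds shown leave open whether a furan-2-yl or thiophen-3-yl group would read the same way, and whether an amine or a carboxylic acid on this aromatic carbon would move the number further. They also leave open whether these steps would hold with the shared core changed elsewhere.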